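Stepwise loss of methoxy groups: compound 3 to compound 4

The source may report more compounds than this note shows. Statements on the series, on what has been measured and on what is new or still open speak of the compounds shown alone.

Three compounds of the series have numbers in a functional assay on PC-3 cells (Homo sapiens) for cytotoxicity, read by sulforhodamine B assay, with a stated time of 48 h; on this read-out lower numbers stand for stronger inhibition and higher numbers for weaker inhibition. Compound 1 `O=CCN1N=C(c2ccc3ccccc3c2)CC1c1ccccc1[N+](=O)[O-]` gives 3010 nM. Compound 2 `COc1cc(C2CC(c3ccc4ccccc4c3)=NN2CC=O)cc(OC)c1OC` gives 570 nM. Compound 3 `COc1ccc(C2CC(c3ccc4ccccc4c3)=NN2CC=O)cc1OC` gives 1980 nM, the second highest of the three numbers, although compound 1 lies within the scatter of it; compound 2 stands beyond the scatter, the recorded step being a 3.5-fold higher number from compound 2 to compound 3 (0.54 log units; beyond the scatter) for the change of one methoxy to hydrogen.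

Compound 4 `COc1ccc(C2CC(c3ccc4ccccc4c3)=NN2CC=O)cc1` has not yet been measured. It differs from compound 3 by hydrogen in place of methoxy on an aromatic carbon. For the measured compounds named here, this is the same kind of change as the one measured step, the step from compound 2 to compound 3, which raised the number beyond the scatter by a modest amount. Going by the values given here, no other pair bears on it. The expectation for compound 4 is therefore a rise of similar size, about a 2.8-fold higher number from compound 3 to compound 4 (0.44 log units; beyond the scatter), and not a fall. The estimate for compound 4 in this assay is 5500 nM, with a range from 2200 nM to 14000 nM. Among the compounds with values here, the direction rests on a single measured pair, and no compound among the three contradicts it.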

Compound 4, half-maximal inhibitory concentration: 4530 nM
For compound 4 the middle estimate is 1.2-fold (0.08 log units) above the measured one; the measured number falls inside the stated range.
By their numbers in this assay, from the lowest: compound 2; then compounds 3, 1 and 4 (each within the scatter of the next, the first and the last beyond it).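

In this assay the loss of a further methoxy moves the number the same way as the earlier loss: a 2.3-fold higher number from compound 3 to compound 4 (0.36 log units; beyond the scatter) follows a 3.5-fold higher number from compound 2 to compound 3 (0.54 log units; beyond the scatter), so hydrogen in place of methoxy now rests on two steps, both beyond the scatter, and nothing among compounds 2, 3 and 4 goes against that direction. The change in the new step sits on an aromatic carbon ortho to a methoxy group and meta to a large group, and it shows that the trend does not stop once the first methoxy has gone. Exchanging the whole substituent gives a different picture, as a 1.5-fold higher number from compound 1 to compound 4 (0.18 log units; within the scatter) lies within the scatter, so 4-methoxyphenyl and 2-nitrophenyl on a saturated ring carbon cannot be told apart here, and nothing at hand explains either step.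

Still open, from the compounds shown here alone, is whether the remaining methoxy of compound 4 contributes anything to the number, and whether a hydroxy group or an amine on the same aromatic carbon would follow the direction seen with hydrogen. Going by these compounds, whether a carboxylic acid in place of the aldehyde of the shared side chain would keep the number is also open.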